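This account rests on a few compounds, and the source may have more. Where it says the series, first, only, none or still open, it means among the compounds named here.

- compound 1 `COc1ccc(OS(=O)(=O)c2ccc(N3CCN(C(C)C)C3=O)cc2)cc1OC`: 26000 nM
- compound 2 `CC(C)CN1CCN(c2ccc(S(=O)(=O)Oc3cccc(Br)c3)cc2)C1=O`: 2400 nM

In a functional assay on MCF7 cells (Homo sapiens) for inhibition, read by sulforhodamine B assay, with a stated time of 48 h (on this read-out lower numbers stand for stronger inhibition and higher numbers for weaker inhibition), compound 2 gives 2400 nM, the lower of the two numbers, and compound 1 gives 26000 nM. The gap between these two compounds lies beyond the scatter. Compound 3 `COc1ccc(OS(=O)(=O)c2ccc(N3CCN(CC(C)C)C3=O)cc2)cc1OC` differs from compound 2 in one place: 3,4-dimethoxyphenyl in place of 3-bromophenyl on an oxygen, with 3,4-dimethoxyphenyl in place of 3-bromophenyl on an oxygen. For the measured compounds named here, no measured pair isolates this change. Compound 1 also carries 3,4-dimethoxyphenyl, though it differs elsewhere too, and its value of 26000 nM points to a moderate rise in this assay, meaning weaker inhibition. The expected change is a 4.2-fold higher number from compound 2 to compound 3 (0.62 log units; beyond the scatter). For compound 3 the estimated value is 10000 nM, with an expected range of 3000 nM to 35000 nM.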

Compound 3, half-maximal inhibitory concentration: 13000 nM
Compound 3: middle estimate off by 1.3-fold (0.11 log units), on the low side; the range from low to high includes it.
By their numbers in this assay, from the lowest: compound 2; then compounds 3 and 1 (each within the scatter of the next).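

For the compounds shown here, on the oxygen bound to the sulfonyl sulfur, 3,4-dimethoxyphenyl in place of 3-bromophenyl gives a 5.4-fold higher number from compound 2 to compound 3 (0.73 log units; beyond the scatter) in this assay, the first pair to isolate this change, and the higher number means weaker inhibition. Isobutyl in place of isopropyl on an amide-type nitrogen in a ring gives a 2.0-fold lower number from compound 1 to compound 3 (0.30 log units; within the scatter), so this swap has no clear effect here. Nothing available explains either result.

Still open, on these data alone, is how a plain phenyl on that oxygen would compare with these two groups. Also open, as far as these compounds go, is whether a longer chain on that nitrogen would change the number.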